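A few compounds are considered here, and "the series" means these few. Any claim that something is new, unique, unknown or untested is made for them only; others in the source may bear on it.

Measured so far in a functional assay on CHO cells for agonist activity at Free fatty acid receptor 1 (Homo sapiens), read by calcium flux; on this read-out higher numbers stand for an effect only at larger amounts of compound and lower numbers for an effect already at smaller amounts:
Compound 1 `O=C(O)CCc1ccc(OCc2nnc(C(=O)Nc3ccc(Cl)cc3)s2)cc1`, giving 3690 nM.
Compound 2 `COc1cccc(NC(=O)c2nnc(COc3ccc(CCC(=O)O)cc3)s2)c1`, giving 4680 nM.

Compound 2 gives the higher of the two numbers shown, but the step of a 1.3-fold higher number from compound 1 to compound 2 (0.10 log units; within the scatter) lies within the scatter, so no real difference between compound 2 and compound 1 can be read from it. Compound 3 `O=C(O)CCc1ccc(OCc2nnc(C(=O)Nc3ccc(F)c(F)c3)s2)cc1` has not yet been measured. It differs from compound 2 in one place: 3,4-difluorophenyl in place of 3-methoxyphenyl on an amide-type nitrogen. For the measured compounds named here, the only measured step that bears on this change is the exchange of the group on the amide-type nitrogen, which gave a 1.3-fold higher number from compound 1 to compound 2 (0.10 log units; within the scatter); the two groups tried there, 4-chlorophenyl and 3-methoxyphenyl, left the read-out in this assay essentially where it was. Compound 3 carries a third group at the same place, 3,4-difluorophenyl, and on that single precedent no step beyond the scatter is expected. Compound 3 is therefore estimated at 3800 nM, with a range from 1500 nM to 9500 nM. That estimate for compound 3 means an expected step of a 1.2-fold lower number from compound 2 to compound 3 (0.09 log units; within the scatter), within the scatter.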

Compound 3, half-maximal effective concentration: 580 nM
Estimate against measurement, compound 3: 6.6-fold (0.82 log units) above, outside the stated range (below it).
By their numbers in this assay, from the lowest: compound 3; then compounds 1 and 2 (each within the scatter of the next).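

In this assay, the group on the amide-type nitrogen proved able to move the read-out: 3,4-difluorophenyl gave an 8.1-fold lower number from compound 2 to compound 3 (0.91 log units; beyond the scatter) when it replaced 3-methoxyphenyl and a 6.4-fold lower number from compound 1 to compound 3 (0.80 log units; beyond the scatter) when it replaced 4-chlorophenyl. The earlier exchange, with a 1.3-fold higher number from compound 1 to compound 2 (0.10 log units; within the scatter), had suggested that this position made little difference, but that impression held only for the two groups compared there. The exchange of 3-methoxyphenyl for 3,4-difluorophenyl keeps the same count of heavy atoms and a six-membered aromatic ring of carbon only, so neither of those features separates compound 2 from compound 3, and no supporting data are available to explain the difference.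

The compounds shown do not reveal whether both fluorines are needed, since a single fluorine as in 3-fluorophenyl or 4-fluorophenyl does not appear among them, and neither does 3,4-dichlorophenyl, which would show whether another halogen at the same two places serves equally well. As far as these compounds go, it also remains open whether the gain seen with 3,4-difluorophenyl would carry over to a core with a longer chain in place of the propanoic acid.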